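This account rests on a few compounds, and the source may have more. Where it says the series, first, only, none or still open, it means among the compounds named here.

Compound 3 `CCCCS(=O)(=O)Oc1ccc(/C=C/C(=O)Nc2ccccc2Br)cc1OC` gives the lowest number of the three measured compounds in a toxicity assay on L02 cells (Homo sapiens) for cytotoxicity, read by MTT assay, with a stated time of 24 h (on this read-out higher numbers stand for lower toxicity in this test and lower numbers for higher toxicity in this test), with 5000 nM. Compound 1 `CCCCS(=O)(=O)Oc1ccc(/C=C/C(=O)Nc2ccc(CC)cc2)cc1OC` gives 89000 nM in this assay, and compound 2 `CCCCOC(=O)/C=C/c1ccc(OS(=O)(=O)c2ccc(Cl)cc2)c(OC)c1` gives 14000 nM. Compound 4 `CCCCS(=O)(=O)Oc1ccc(/C=C/C(=O)OCC(C)C)cc1OC` differs from compound 3 by isobutoxy in place of (2-bromophenyl)amino on a carbonyl carbon. Among the measured compounds shown here, the only step measured in this assay, an 18-fold lower number from compound 1 to compound 3 (1.25 log units; beyond the scatter), alters the group on the amide nitrogen, whereas here the whole amide is replaced by an ester, so it bears on the change only loosely. Compound 2, also an ester, stands between compound 3 and compound 1. A moderate rise is therefore expected, a 4.0-fold higher number from compound 3 to compound 4 (0.60 log units; beyond the scatter), though the scatter leaves this uncertain. Compound 4 is estimated at 20000 nM, within 5000 nM to 80000 nM.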

Compound 4, half-maximal cytotoxic concentration: 63800 nM
The estimate for compound 4 lay 3.2-fold (0.50 log units) below the measured number; the range from low to high includes it.
By their numbers in this assay, from the lowest: compound 3; then compound 2; then compounds 4 and 1 (each within the scatter of the next).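

In this assay the change to isobutoxy on a carbonyl carbon gives a 13-fold higher number from compound 3 to compound 4 (1.11 log units; beyond the scatter) when it replaces (2-bromophenyl)amino, but a 1.4-fold lower number from compound 1 to compound 4 (0.14 log units; within the scatter) when it replaces (4-ethylphenyl)amino. Replacing the amide with this ester therefore does not shift the number by a single amount; the outcome depends on which amide it replaces, and only compound 3 stands apart. Nothing available explains this difference. As far as these compounds go, it remains open how a carboxylic acid or a methoxy group on this carbonyl carbon would read. From the compounds shown here alone, it also remains open whether the bromine itself accounts for the low number of compound 3.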